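The source may report more compounds than this note shows. Statements on the series, on what has been measured and on what is new or still open speak of the compounds shown alone.

Going by the values given here, in a functional assay on HeLa cells (Homo sapiens) for cytotoxicity, read by WST assay, with a stated time of 48 h (on this read-out lower numbers stand for an effect already at smaller amounts and higher numbers for an effect only at larger amounts of compound), compound 3 `COc1ccccc1C[C@H]1COC(=O)[C@@H]1Cc1ccc(Cl)c(Cl)c1` gives 24000 nM, the only number available so far. Compound 1 `O=C1OC[C@H](Cc2ccccc2)[C@H]1Cc1ccc(OC(F)(F)F)cc1` stands at "not determined" (no result reported) and compound 2 `CCCCOc1cc(C[C@H]2C(=O)OC[C@@H]2Cc2ccccc2)ccc1O` at "not determined" (no result reported), so compound 3 cannot yet be ranked against anything. Compound 4 `CCCCOc1ccccc1C[C@H]1COC(=O)[C@@H]1Cc1ccc(Cl)c(Cl)c1` keeps the core of compound 3 and differs in one place: propyl in place of hydrogen on a saturated chain carbon bound to an oxygen on an aromatic ring, which lengthens methoxy to butoxy. Among the compounds with values here, no pair of measured compounds shows what a change of this kind does, so any forecast rests on little. A modest move towards lower numbers in this assay is expected, possibly no larger than the usual scatter. The estimated step is a 1.6-fold lower number from compound 3 to compound 4 (0.20 log units; within the scatter). The expected value for compound 4 is 15000 nM, within a range of 6000 nM to 40000 nM.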

Compound 4, half-maximal effective concentration: > 100000 nM
Compound 4: no number, only a limit; the forecaster's own chance of this, stated with the estimate: 20%; middle value at least 6.6-fold (0.82 log units) from the limit.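

In this assay, lengthening methoxy to butoxy on a saturated chain carbon bound to an oxygen on an aromatic ring does not help: the change gives an at least 4.1-fold higher number from compound 3 to compound 4 (0.61 log units; beyond the scatter). This place on the compound therefore responds to the length of the chain. Compound 4 gives only a limit, not a number, so the full size of this step stays unknown: the limit of > 100000 nM in this assay, at which 1 of the 4 values shown sits.

As far as these compounds go, whether ethoxy, a chain of intermediate length, keeps the effect stays open. So does what an amine at the end of the chain would do.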